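The source may report more compounds than this note shows. Statements on the series, on what has been measured and on what is new or still open speak of the compounds shown alone.

Measured so far:
compound 1, `CCCCCNc1nc(N)nc2ccccc12`, 0.1 uM
compound 2, `CCCCNc1nc(N)nc2ccc(CO)cc12`, 0.2 uM

Of the two numbers in an ADME assay on HEK293 cells for agonist activity at Toll-like receptor 8 (Homo sapiens), read by a luciferase reporter, with a stated time of 6 h (a higher number here means that more compound is needed for the effect, a lower number that less compound is needed), that of compound 2 is the larger, but compound 1 lies within the scatter of it, so the two are not told apart. Compound 3, `CCCCNc1nc(N)nc2ccc(CCc3ccccn3)cc12`, is not yet measured. It differs from compound 2 by (pyridin-2-yl)methyl in place of hydroxy on a saturated chain carbon bound to an aromatic carbon; cut one bond further out, the same difference reads hydroxymethyl to 2-(pyridin-2-yl)ethyl. Among the compounds with values here, no measured pair here carries such a change, so no step size can be read off. For this assay the expectation is a step no larger than the scatter, in either direction. Compound 3 is estimated at 0.2 uM, within 0.05 uM to 0.8 uM, which means an expected step of no change at the digits printed from compound 2 to compound 3 (within the scatter).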

Compound 3, minimum effective concentration: 0.3 uM
Compound 3: the middle estimate sits 1.5-fold (0.18 log units) below what was measured; measured number inside the range.
By their numbers in this assay, from the lowest: compounds 1, 2 and 3 (each within the scatter of the next, the first and the last beyond it).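

Putting (pyridin-2-yl)methyl in place of hydroxy on a saturated chain carbon bound to an aromatic carbon gives a 1.5-fold higher number from compound 2 to compound 3 (0.18 log units; within the scatter) in this assay. This place therefore takes a six-membered aromatic ring, and loses the hydrogen-bond donor of hydroxy, without compound 2 and compound 3 being told apart. No available evidence accounts for this result.

On these data alone, whether an amine, a carboxylic acid or a longer chain at this place would also stay within the scatter remains open. So does whether a phenyl group would read like the pyridin-2-yl ring.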